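The source may hold more compounds than are shown below. What is called first, only, known or untested is meant among the compounds shown, and "the series" means these compounds.

Among the measured compounds shown here, compound 2 `COc1ccc(NC(=O)Nc2cccc(CNc3ncnc4ccccc34)c2)cc1` is the one compound here that gives a number in a functional assay on MGC-803 cells (Homo sapiens) for antiproliferative activity, read by MTT assay (a higher number here means a weaker inhibitor, a lower number a stronger inhibitor), namely 27300 nM. Compound 1 `Cc1ccccc1NC(=O)Nc1cccc(CNc2ncnc3ccccc23)c1` gives only a limit, > 50000 nM, in this assay (the limit of > 50000 nM in this assay, at which 1 of the 2 values shown sits). For the measured compounds named here, the one measured step, an at least 1.8-fold lower number from compound 1 to compound 2 (0.26 log units; that floor lies within the scatter), thus has a floor within the scatter. Compound 3 `O=C(Nc1ccc(F)cc1)Nc1cccc(CNc2ncnc3ccccc23)c1` differs from compound 2 by fluoro in place of methoxy on an aromatic carbon. Going by the values given here, no measured step touches the methoxy or fluoro position, so little guidance exists; compound 3 is expected to stay close to compound 2, with a step of a 1.3-fold higher number from compound 2 to compound 3 (0.11 log units; within the scatter) and an estimate of 35000 nM between 12000 nM and 90000 nM in this assay.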

Compound 3, half-maximal inhibitory concentration: 44300 nM
Compound 3: middle estimate off by 1.3-fold (0.10 log units), on the low side; low and high end bracket the measured number.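

On the aromatic carbon para to a large group, fluoro in place of methoxy now gives a measured step in this assay (a 1.6-fold higher number from compound 2 to compound 3 (0.21 log units; within the scatter)), and that step does not separate the two groups. The change from 2-methylphenyl to 4-fluorophenyl gives only a floor (an at least 1.1-fold lower number from compound 1 to compound 3 (0.05 log units; that floor lies within the scatter)), so it fixes no size for that change. That floor exists because compound 1 gives a limit and not a number: the limit of > 50000 nM in this assay, at which 1 of the 3 values shown sits.

From the compounds shown here alone, whether an amine, a carboxylic acid or a longer chain such as ethoxy at this position would move the number beyond the scatter stays open.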